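The source may report more compounds than this note shows. Statements on the series, on what has been measured and on what is new or still open speak of the compounds shown alone.

Measured compounds:
compound 1 `CCOC(=O)CCC(=O)N1CCN(CCCOc2cc3c(Nc4ccc(F)c(Cl)c4)ncnc3cc2OC)CC1`: 77.6%
compound 2 `CCCCCOC(=O)CCC(=O)N1CCN(CCCOc2cc3c(Nc4ccc(F)c(Cl)c4)ncnc3cc2OC)CC1`: 87.1%
compound 3 `CCCCCCCCCCCOC(=O)CCC(=O)N1CCN(CCCOc2cc3c(Nc4ccc(F)c(Cl)c4)ncnc3cc2OC)CC1`: 93.4%

The three compounds share one core and differ only at the ester end of the chain. In a functional assay on A549 cells (Homo sapiens) for cytotoxicity, read by MTT assay, with a stated time of 24 h, tested at 10 uM (a lower number here means a stronger effect, a higher number a weaker effect of the compound at the concentration tested), compound 1 gives 77.6%, compound 2 gives 87.1% and compound 3 gives 93.4%. Compound 3 holds the highest of the three numbers. Its nearest neighbour is compound 2, and a number 6.3 percentage points higher from compound 2 to compound 3 (within the scatter) is within the scatter; the step of a number 15.8 percentage points higher from compound 1 to compound 3 (beyond the scatter) is beyond it. Within the data shown here, since only one of the two steps to compound 3 is beyond the scatter, compound 3 cannot be called the weakest of the set on these numbers.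

Compound 4 `CCCCCCCCCCCCCOC(=O)CCC(=O)N1CCN(CCCOc2cc3c(Nc4ccc(F)c(Cl)c4)ncnc3cc2OC)CC1` is not yet measured. It differs from compound 3 by ethyl in place of hydrogen on a saturated chain carbon, ten or more bonds along the chain from an oxygen next to a carbonyl group. Among the measured compounds shown here, the steps that bear on this are a number 9.5 percentage points higher from compound 1 to compound 2 (within the scatter), a number 6.3 percentage points higher from compound 2 to compound 3 (within the scatter) and a number 15.8 percentage points higher from compound 1 to compound 3 (beyond the scatter). Each of those changes moved the number upward, but the one nearest in kind to the present change, a number 6.3 percentage points higher from compound 2 to compound 3 (within the scatter), stayed within the scatter, and the present change adds less than any of them. A small upward step in this assay, within the scatter or none at all, is therefore expected.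

Compound 4 is expected to give about 95.5%, with a range of 86% to 103%. That estimate means an expected step of a number 2.1 percentage points higher from compound 3 to compound 4 (within the scatter).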

Compound 4, a percentage reported as activity, at one concentration (the size of the read-out at that concentration, not a potency): 93.7%
Compound 4: middle estimate off by 1.8 percentage points, on the high side, within the range that was stated.
By their numbers in this assay, from the lowest: compounds 1, 2, 3 and 4 (each within the scatter of the next, the first and the last beyond it).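

In this assay, ethyl in place of hydrogen on a saturated chain carbon, ten or more bonds along the chain from an oxygen next to a carbonyl group, gives a number 0.3 percentage points higher from compound 3 to compound 4 (within the scatter) and so does not separate the two compounds. Read from nearer the oxygen, octyl in place of hydrogen five bonds along the chain gives a number 6.6 percentage points higher from compound 2 to compound 4 (within the scatter) and undecyl in place of hydrogen two bonds along the chain gives a number 16.1 percentage points higher from compound 1 to compound 4 (beyond the scatter) as the only one of the three steps that clears the scatter, which leaves compound 1 as the sole compound in the set that compound 4 can be told apart from. No accompanying measurement bears on what lies behind these numbers.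

On these data alone, whether a longer chain at this position would also leave the read-out within the scatter of compound 4 stays open. Also open, as far as these compounds go, is whether a carboxylic acid or an amine at the end of the chain, in place of the alkyl ester, would move the read-out in either direction beyond the scatter.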